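A few compounds are considered here, and "the series" means these few. Any claim that something is new, unique, unknown or untested is made for them only; others in the source may bear on it.

Measured compounds in an assay for inhibition of RAC-alpha serine/threonine-protein kinase (Homo sapiens), read by HTRF, with a stated time of 1 h; a lower number here means a stronger inhibitor, a higher number a weaker inhibitor:
Compound 1, `C=CC[C@@H]1C[C@@H](c2ccc(Cl)c(Cl)c2)[C@H](NC(=O)c2cc(-c3c(Cl)cnn3C)c(Cl)o2)CN1`, gives 12.4 nM.
Compound 2, `Cn1ncc(Cl)c1-c1cc(C(=O)N[C@@H]2CN[C@H](CC(=O)NCC(O)CO)C[C@H]2c2ccc(Cl)c(Cl)c2)oc1Cl`, gives 3.13 nM.

Compound 2 stands lowest of the two numbers in this assay; its nearest neighbour is compound 1, and the step from one to the other is a 4.0-fold lower number from compound 1 to compound 2 (0.60 log units; beyond the scatter), which is beyond the scatter. The structural change that produced that step was the replacement of vinyl on a saturated chain carbon bound to a saturated ring carbon by the (2,3-dihydroxypropyl)carbamoyl group.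

Compound 3, `COCC[C@@H]1C[C@@H](c2ccc(Cl)c(Cl)c2)[C@H](NC(=O)c2cc(-c3c(Cl)cnn3C)c(Cl)o2)CN1`, is not yet measured. It differs from compound 2 as follows: methoxymethyl in place of (2,3-dihydroxypropyl)carbamoyl on a saturated chain carbon bound to a saturated ring carbon. Among the compounds with values here, the only measured step that bears on this change is a 4.0-fold lower number from compound 1 to compound 2 (0.60 log units; beyond the scatter), in which the larger polar group lowered the number relative to the small vinyl group. Methoxymethyl is closer in size to vinyl than to the group it replaces, so the expectation is that compound 3 moves back part of the way toward compound 1, a step of a 2.6-fold higher number from compound 2 to compound 3 (0.41 log units; beyond the scatter). On that basis compound 3 is expected to give about 8 nM in this assay, within a range of 3 nM to 25 nM.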

Compound 3, half-maximal inhibitory concentration: 7.01 nM
Estimate against measurement, compound 3: 1.1-fold (0.06 log units) above, within the range that was stated.
By their numbers in this assay, from the lowest: compound 2; then compounds 3 and 1 (each within the scatter of the next).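

In this assay, putting methoxymethyl on the saturated chain carbon bound to a saturated ring carbon gives a 2.2-fold higher number from compound 2 to compound 3 (0.35 log units; beyond the scatter), so the (2,3-dihydroxypropyl)carbamoyl group now keeps the lower number against a second group and not against vinyl alone. Methoxymethyl in place of vinyl gives a 1.8-fold lower number from compound 1 to compound 3 (0.25 log units; within the scatter), so these two groups cannot be told apart at this position. Among these three compounds only compound 2 stands apart from the others, and it carries the group with the most heavy atoms and the only hydrogen-bond donors of the two groups compared under this change, although three compounds are too few to tie the number to either count.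

No independent measurement accounts for these differences in the number, and the reason for them remains unknown. The compounds leave open which part of the (2,3-dihydroxypropyl)carbamoyl group carries the difference, and whether a 2-hydroxyethyl group, a plain carbamoyl group or a carboxylic acid at this position would stay with compound 2 or fall level with compound 1 and compound 3.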